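The source may hold more compounds than are shown below. What is called first, only, known or untested is meant among the compounds shown, and "the series" means these compounds.

Measured in a functional assay on DLA cells (Mus musculus) for cytotoxicity, read by LDH release, with a stated time of 48 h; on this read-out higher numbers stand for weaker inhibition and lower numbers for stronger inhibition:
compound 1 `Cc1ccc(OCC(=O)NNC(=O)c2cc3ccccc3oc2=O)c(C(=O)c2ccccc2Br)c1`: 10600 nM
compound 2 `Cc1ccc(OCC(=O)NNC(=O)c2cc3ccccc3oc2=O)c(C(=O)c2cccc(Br)c2)c1`: 69800 nM
compound 3 `Cc1ccc(OCC(=O)NNC(=O)c2cc3ccccc3oc2=O)c(C(=O)c2ccc(Br)cc2)c1`: 95300 nM

Compound 3 sits level with compound 2 in this series, with a 1.4-fold higher number from compound 2 to compound 3 (0.14 log units; within the scatter). Both stand apart from compound 1, with a 9.0-fold higher number from compound 1 to compound 3 (0.95 log units; beyond the scatter) and a 6.6-fold higher number from compound 1 to compound 2 (0.82 log units; beyond the scatter). Compound 3 therefore belongs to the weaker pair of the three.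

Next comes compound 4 `Cc1ccc(C(=O)c2cc(C)ccc2OCC(=O)NNC(=O)c2cc3ccccc3oc2=O)cc1`, which carries 4-methylphenyl where compound 3 carries 4-bromophenyl: methyl in place of bromo on an aromatic carbon. In words, this is methyl in place of bromo on an aromatic carbon, para to a large group.

Among the measured compounds shown here, no measured step makes this exchange, so the evidence is indirect. All three steps change where the bromo sits, whereas here the position stays and the group changes. The two modest steps both start from compound 1, and compound 4 keeps the position found in compound 3. For the measured compounds named here, the only step between the two compounds lacking the position of compound 1 is a 1.4-fold higher number from compound 2 to compound 3 (0.14 log units; within the scatter), which stays within the scatter. No direction can be assigned from these data.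

The expected change is a 1.2-fold lower number from compound 3 to compound 4 (0.08 log units; within the scatter), and no step beyond the scatter is anticipated in this assay. The estimate for compound 4 is 80000 nM, with an expected range from 30000 nM to 190000 nM.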

Compound 4, half-maximal inhibitory concentration: 87200 nM
Estimate against measurement, compound 4: 1.1-fold (0.04 log units) below; low and high end bracket the measured number.
By their numbers in this assay, from the lowest: compound 1; then compounds 2, 4 and 3 (each within the scatter of the next).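

Working from this assay, compound 4 gives the first reading in which the group changes while the place stays fixed: on an aromatic carbon, para to a large group, methyl in place of bromo gives a 1.1-fold lower number from compound 3 to compound 4 (0.04 log units; within the scatter), so this pair stands level and bromo is not required for the number seen with compound 3. Compound 4 also stands level with compound 2, at a 1.2-fold higher number from compound 2 to compound 4 (0.10 log units; within the scatter), while the gap to the 2-bromophenyl compound persists, at an 8.2-fold higher number from compound 1 to compound 4 (0.92 log units; beyond the scatter); among these four compounds, only compound 1 stands apart from the others. Nothing available explains why the 4-bromophenyl and 4-methylphenyl compounds stand level.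

Going by these compounds, it remains open whether 2-methylphenyl on the same carbonyl carbon would stand with compound 1 or with the other three, so the separation of compound 1 cannot yet be assigned to the place alone or to bromo in that place. Also open, on these data alone, is whether an amine or a carboxylic acid in place of the bromo of compound 3 would stay level with compound 3 and compound 4.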